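The compounds below may be only part of what the source reports. "The series", "measured", "known", "first", "only" and "open" are said of these compounds alone.

Compound 1 `CC1CCN(C2CCN(S(=O)(=O)c3cccc(C(F)(F)F)c3)CC2)CC1` reads > 5000 nM
Compound 2 `Cc1cc(C)c(S(=O)(=O)N2CCC(N3CCC(c4ccccc4)CC3)CC2)c(C)c1` reads > 5000 nM
Compound 3 `Cc1c(C)c(S(=O)(=O)N2CCC(N3CCC(C)CC3)CC2)c(C)c2c1OC(C)(C)C2` reads > 10000 nM

In an ADME assay on HCT-116 cells (Homo sapiens) for cytotoxicity, read by CellTiter-Glo, with a stated time of 72 h (on this read-out higher numbers stand for weaker inhibition and lower numbers for stronger inhibition), compound 1 stands at > 5000 nM as a limit of the assay and not a number. Compound 2 and compound 3 also give limits and no numbers, so the three cannot be ranked against one another.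

Compound 4 `CC1CCN(C2CCN(S(=O)(=O)c3cccc(N)c3)CC2)CC1` keeps the core of compound 1 and differs from it in one place. It carries amino in place of trifluoromethyl on an aromatic carbon, meta to a large group (amino in place of trifluoromethyl on an aromatic carbon). Among the compounds with values here, no two measured compounds differ in a single place, so no measured step is available as a guide.

The expectation rests on compound 1, which reads > 5000 nM as a limit, and on the absence of any number among its measured companions. In this assay the expected change is none beyond the scatter, with an estimated step that the limit leaves unreadable from compound 1 to compound 4 as its size. Compound 4 is estimated at 8000 nM with an expected range from 3000 nM to 20000 nM, and a limit is expected again.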

Compound 4, half-maximal inhibitory concentration: > 5000 nM
Compound 4: no number, only a limit (the forecaster's own chance of this, stated with the estimate: 85%); the middle value does not contradict the limit.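

In this assay compound 4 gives > 5000 nM, a limit of the assay and not a number. Within the data shown here, compound 1 also gives only a limit, so no step from compound 1 to compound 4 can be read. The compounds shown leave open whether amino in place of trifluoromethyl changes the read-out at all.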